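Cytotoxicity notes on an alkenyl-cyclopropane nucleoside series

This account rests on a few compounds, and the source may have more. Where it says the series, first, only, none or still open, it means among the compounds named here.

Measured compounds in an ADME assay on HFF cells (Homo sapiens) for cytotoxicity, with a stated time of 8 days; a lower number here means that less compound is tolerated, a higher number that more compound is tolerated:
compound 1, `Nc1nc(NC2CC2)c2ncn(/C=C3/CC3(CO)CO)c2n1`, gives > 300000 nM, which is a limit of the assay.
compound 2, `CC(C)CNc1nc(N)nc2c1ncn2/C=C1/CC1(CO)CO`, gives > 300000 nM, which is a limit of the assay.
compound 3, `CSc1nc(N)nc2c1ncn2/C=C1/CC1(CO)CO`, gives > 300000 nM, which is a limit of the assay.

Compound 2 therefore stands at a limit only, with no number of its own, and the same holds for the two other values shown; all three sit at the limit of > 300000 nM in this assay, at which 3 of the 3 values shown sit. The step under study leads from compound 2 to compound 4, `CC(C)Nc1nc(N)nc2c1ncn2/C=C1/CC1(CO)CO`. The change is isopropyl in place of isobutyl on a nitrogen on an aromatic ring. The measured steps that touch the same part of the shared core are a step that the two limits leave unreadable from compound 1 to compound 2, which also exchanges the group on that nitrogen, and a step that the two limits leave unreadable from compound 2 to compound 3 together with a step that the two limits leave unreadable from compound 1 to compound 3, which replace the whole amino substituent. None of the three is readable in size, because every end point sits at the limit of > 300000 nM in this assay, at which 3 of the 3 values shown sit. Among the compounds with values here, there is thus no step in this assay on which a direction or a size could be calibrated; the only expectation available is that compound 4 behaves as compound 2 does. For compound 4 the estimate in this assay is 300000 nM, with a range from 150000 nM to 600000 nM. The step this estimate implies is expected to be a number no higher from compound 2 to compound 4 (the limit leaves the size open), in all likelihood again reported as a limit rather than a number.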

Compound 4, half-maximal cytotoxic concentration: > 300000 nM
Compound 4 gave a limit, no number; the forecaster's own chance of this, stated with the estimate: 85%; the middle value lies on the limit itself.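

No step from compound 1, compound 2 or compound 3 to compound 4 can be read in this assay, since every end point is a limit and not a number: the limit of > 300000 nM in this assay, at which 4 of the 4 values shown sit.

The compounds shown leave open where any of these four would reach a half-maximal cytotoxic concentration, and whether isopropyl and isobutyl on a nitrogen on an aromatic ring differ at all.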